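Adding a Methoxy Group to Compound 2

The compounds below may be only part of what the source reports. "The series", "measured", "known", "first", "only" and "open" are said of these compounds alone.

Of the compounds shown here, two sharing one core have been measured in a functional assay on the whole organism (strain Sprague-Dawley) for inhibition, with Rattus norvegicus as the target, with a stated time of 10 min; on this read-out higher numbers stand for an effect only at larger amounts of compound and lower numbers for an effect already at smaller amounts. Compound 1 `COc1ccccc1-c1ncc(C(=O)O)c(=O)[nH]1` gives 10 mg/kg, and compound 2 `COc1cccc(-c2ncc(C(=O)O)c(=O)[nH]2)c1` gives 10 mg/kg, so compound 2 stands level with compound 1 at the digits reported. The next compound, compound 3 `COc1ccc(OC)c(-c2ncc(C(=O)O)c(=O)[nH]2)c1`, keeps the core of compound 2 and carries methoxy in place of hydrogen on an aromatic carbon. The new group sits ortho to a large group and para to a methoxy group. Going by the values given here, no measured pair yet shows what such a change does, and the level values give no direction. No step beyond the scatter is therefore expected in this assay, and the estimated change is no change at the digits printed from compound 2 to compound 3 (within the scatter). Compound 3 is expected at 10 mg/kg, with an estimated range from 3 mg/kg to 30 mg/kg.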

Compound 3, dose for 50% inhibition: 1 mg/kg
Compound 3: the middle estimate sits 10-fold (1.00 log units) above what was measured, and the stated range ends above it.
By their numbers in this assay, from the lowest: compound 3; then compounds 1 and 2 (each within the scatter of the next).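

In this assay, methoxy in place of hydrogen on an aromatic carbon, ortho to a large group and para to a methoxy group, brings a 10-fold lower number from compound 2 to compound 3 (1.00 log units; beyond the scatter), so this position responds to the change in a way the level values of the two earlier compounds could not show. The comparison with the other earlier compound points the same way, with a 10-fold lower number from compound 1 to compound 3 (1.00 log units; beyond the scatter), and the lowest number of the three thus belongs to the compound carrying both methoxy groups. Nothing available bears on why the number falls.

The compounds shown leave open whether methoxy itself is needed at this place, or whether a hydroxy group, a fluorine atom or an ethoxy group would serve as well. They also leave open whether the new group would bring such a step without the methoxy group para to it.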